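The compounds below may be only part of what the source reports. "The series", "measured", "known", "first", "only" and "open" are said of these compounds alone.

Compound 1 `CCNc1nc(Nc2ccc(C#N)cc2)nc(Oc2ccc3ccccc3c2Cl)n1` is the more tolerated of the two measured compounds: in an ADME assay on MT4 cells (Homo sapiens) for cytotoxicity, read by MTT assay, with a stated time of 4 days (a higher number here means that more compound is tolerated, a lower number that less compound is tolerated), compound 1 gives 188000 nM. Compound 2 `N#Cc1ccc(Nc2nc(N)nc(Oc3ccc4ccccc4c3Cl)n2)cc1` gives 32200 nM in this assay, so that a 5.8-fold lower number from compound 1 to compound 2 (0.77 log units; beyond the scatter). Within the data shown here, on these two numbers compound 2 therefore stands lowest, with compound 1 the only neighbour and that one well beyond the scatter.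

Compound 3 `N#Cc1ccc(Nc2nc(N=[N+]=[N-])nc(Oc3ccc4ccccc4c3Cl)n2)cc1` differs from compound 2 in azido in place of amino on an aromatic carbon. Among the measured compounds shown here, the one measured step concerns a different site and a different kind of exchange, so nothing measured bears directly on this change, and no step beyond the scatter is expected in this assay in either direction. Compound 3 is thus expected to give 28000 nM, within a range from 9000 nM to 90000 nM, which would mean a 1.2-fold lower number from compound 2 to compound 3 (0.06 log units; within the scatter), an expectation drawn from compound 2 alone.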

Compound 3, half-maximal cytotoxic concentration: 256000 nM
For compound 3 the middle estimate is 9.1-fold (0.96 log units) below the measured one; the measured number lies above the stated range.
By their numbers in this assay, from the lowest: compound 2; then compounds 1 and 3 (each within the scatter of the next).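

In this assay, the position on the aromatic carbon between two ring nitrogen atoms responds to more than the ethyl exchange already seen: azido in place of amino gives an 8.0-fold higher number from compound 2 to compound 3 (0.90 log units; beyond the scatter), a step beyond the scatter. Azido in place of ethylamino gives a 1.4-fold higher number from compound 1 to compound 3 (0.13 log units; within the scatter), so these two quite different groups cannot be told apart here, and compound 2, with amino, is the one that stands low among the three. Nothing available explains why amino differs from the other two groups.

As far as these compounds go, whether a methoxy group, a dimethylamino group or a longer chain such as butylamino at this position would fall with compound 2 or with compound 1 and compound 3 remains open. Three compounds on one core also cannot show whether the azido step would hold on another core.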